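The source may hold more compounds than are shown below. What is called first, only, known or untested is meant among the compounds shown, and "the series" means these compounds.

Measured compounds in an ADME assay on RAW264.7 cells (Mus musculus) for cytotoxicity, read by resazurin assay, with a stated time of 48 h; a higher number here means that more compound is tolerated, a lower number that less compound is tolerated:
compound 1, `CC(C)(C)OC(=O)NCCCCNCCCN(Cc1ccc(F)cc1)Cc1ccc(F)cc1`, gives 8700 nM.
compound 2, `CC(C)(C)OC(=O)NCCCCNCCCN(Cc1ccc(-c2ccccc2)cc1)Cc1ccc(-c2ccccc2)cc1`, gives only a limit of this assay, > 100000 nM.
compound 3, `NCCCCNCCCN(Cc1ccc(F)cc1)Cc1ccc(F)cc1`, gives 33100 nM.

Compound 3 is compound 1 with hydrogen in place of tert-butoxycarbonyl on an amine nitrogen. That change is measured once: a 3.8-fold higher number from compound 1 to compound 3 (0.58 log units; beyond the scatter). The difference between the core of compound 1 and the core of compound 2 is not broken down here.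

Compound 4, `NCCCCNCCCN(Cc1ccc(-c2ccccc2)cc1)Cc1ccc(-c2ccccc2)cc1`, is not yet measured in this assay. It is compound 2 with hydrogen in place of tert-butoxycarbonyl on an amine nitrogen, the same change as from compound 1 to compound 3, at the same kind of place, an amine nitrogen whose other neighbours are a saturated chain carbon.

For compound 2 the assay reports (the limit of > 100000 nM in this assay, at which 1 of the 3 values shown sits), so no number stands beneath the change. Going by the values given here, the one measured instance of the change moved the value upward by a modest amount, and the expectation for compound 4 is that the step that the limit leaves unreadable from compound 2 to compound 4 is of the same direction and similar size, resting on the measured step from compound 1 to compound 3 and on the fact that compound 2 already sits at the limit. Because the limit of > 100000 nM in this assay, at which 1 of the 3 values shown sits, is where compound 2 stands, the most likely outcome is that compound 4 also returns only a limit rather than a number. The value expected for compound 4 in this assay is 150000 nM, with the range 60000 nM to 400000 nM.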

Compound 4, half-maximal cytotoxic concentration: 4200 nM
For compound 4 the middle estimate is 36-fold (1.55 log units) above the measured one, and the stated range ends above it.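

In this assay, hydrogen in place of tert-butoxycarbonyl on an amine nitrogen gives an at least 23-fold lower number from compound 2 to compound 4 (1.37 log units; beyond the scatter), so the change does not keep its direction from one core to the other in this series. Set beside the earlier step, which is a 3.8-fold higher number from compound 1 to compound 3 (0.58 log units; beyond the scatter), the two pairs disagree in direction and lie well apart: the same change on two cores in this assay, a 3.8-fold higher number (0.58 log units; beyond the scatter) from compound 1 to compound 3 and an at least 23-fold lower number (1.37 log units; beyond the scatter) from compound 2 to compound 4, at least 90-fold (1.95 log units) apart, beyond the scatter of two such steps

A step measured on one of these cores therefore gives no safe estimate for the same step on the other, but one pair per core does not show what in the cores sets the difference, supports no rule for any further core, and fixes no exact size for the second step, as compound 2 is held only by a limit: the limit of > 100000 nM in this assay, at which 1 of the 4 values shown sits.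

Open, from the compounds shown here alone, is how the same change behaves on a third core, for example one carrying chlorine where the core of compound 1 carries fluorine. Also open, going by these compounds, is whether acetyl in place of tert-butoxycarbonyl on that amine nitrogen, or a longer chain at the same place, follows the pair of compound 1 and compound 3 or the pair of compound 2 and compound 4.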